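A few compounds are considered here, and "the series" means these few. Any claim that something is new, unique, unknown or untested is made for them only; others in the source may bear on it.

Measured compounds:
- compound 1, `COc1cc(C)cc(-c2c(-c3ccnc(-c4ccc(N(C)C)cc4)c3)cnn2CC#N)c1`: 6%
- compound 2, `COc1cc(C)cc(-c2nn(CC#N)cc2-c2ccnc(-c3ccc(N(C)C)cc3)c2)c1`: -5%
- compound 3, `Cc1cc(O)cc(-c2nn(CC#N)cc2-c2ccnc(-c3ccc(Oc4ccccc4)cc3)c2)c1`: -97%

Of the compounds shown here, three have been tested in a functional assay on U-251 cells (Homo sapiens) for cytotoxicity, read by sulforhodamine B assay, with a stated time of 48 h, tested at 1 uM; a lower number here means a stronger effect, a higher number a weaker effect of the compound at the concentration tested. Compound 1 gives 6%, the highest of the three numbers, so it shows the weakest effect of the set at this concentration. Compound 2 gives -5%, a number lower than that of compound 1 by a margin beyond the usual scatter. Compound 3 gives -97%, far lower still, and thus by far the strongest effect among the three. Among the measured compounds shown here, none of these three pairs differs in only one place, so no single structural step is tied to a measured change.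

Compound 4, `COc1cc(C)cc(-c2c(-c3ccnc(-c4ccc(C(C)=O)cc4)c3)cnn2CC#N)c1`, has not yet been measured. It differs from compound 1 in one place: acetyl in place of dimethylamino on an aromatic carbon. For the measured compounds named here, nothing among the measured compounds shows what acetyl in place of dimethylamino does here. With no guidance from a comparable step, the expectation for compound 4 is a change of a number 2 percentage points lower from compound 1 to compound 4 (within the scatter), that is, little beyond the scatter in either direction. Compound 4 is therefore estimated at 4%, within a range from -25% to 30%.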

Compound 4, a percentage reported as activity, at one concentration (the size of the read-out at that concentration, not a potency): 4%
Estimate against measurement, compound 4: no gap at the digits printed, within the range that was stated.
By their numbers in this assay, from the lowest: compound 3; then compounds 2, 4 and 1 (each within the scatter of the next, the first and the last beyond it).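

In this assay, among the compounds shown here, acetyl in place of dimethylamino on an aromatic carbon, para to a large group, gives a number 2 percentage points lower from compound 1 to compound 4 (within the scatter) and is the first single change in this set that can be read directly. On the core of compound 1, then, this read-out at this one concentration does not separate the 4-(dimethylamino)phenyl group from the 4-acetylphenyl group, even though a nitrogen-bearing group gives way to one with a carbonyl. No measured evidence here bears on the reason for this result.

As far as these compounds go, it remains open whether a carboxylic acid or a morpholine ring at this position would also leave the number within the scatter. The compounds shown also leave open whether acetyl in place of dimethylamino would read the same on the core of compound 2.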